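The compounds below may be only part of what the source reports. "The series", "measured", "known", "first", "only" and "open" are said of these compounds alone.

Compound 1 `COc1cccc(NC(=O)c2nnn(Cc3ccccc3)c2N)c1` is the starting point here. In an ADME assay on microsomes from liver (Mus musculus, strain CD1) for metabolic stability, read by HPLC, using NADPH, with a stated time of 30 min (a lower number here means slower removal, a higher number faster removal of the compound), compound 1 gives 3.7 mL.min-1.g-1. Going by the values given here, the only other measured member of the series is compound 2 `COc1cccc(NC(=O)c2nnn(Cc3ccc(OC(F)(F)F)cc3)c2N)c1`, which in this assay gives 2.9 mL.min-1.g-1. The two numbers lie close together: a 1.3-fold lower number from compound 1 to compound 2 (0.11 log units; within the scatter). Compound 1 therefore stands with compound 2 inside the usual spread of repeated measurements, and the two cannot be told apart on these numbers.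

Compound 3 `COc1cccc(NC(=O)c2nnn(Cc3ccncc3)c2N)c1` has not yet been measured. It differs from compound 1 in one place: pyridin-4-yl in place of phenyl on a saturated chain carbon bound to an aromatic nitrogen. Among the compounds with values here, the only measured step that touches the same part of the molecule is the one from compound 1 to compound 2, where a group was added on the ring carried by that chain carbon and the number barely moved. Within the data shown here, no measured step swaps a ring carbon for a ring nitrogen, so the expectation rests on that single small step and on the modest size of the change. The step from compound 1 to compound 3 is expected to be a 1.2-fold lower number from compound 1 to compound 3 (0.09 log units; within the scatter), that is, no change beyond the scatter. For compound 3 in this assay the estimate is 3 mL.min-1.g-1, with a range from 1.5 mL.min-1.g-1 to 6 mL.min-1.g-1.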

Compound 3, intrinsic clearance in microsomes: 0.7 mL.min-1.g-1
Compound 3: the middle estimate sits 4.3-fold (0.63 log units) above what was measured; measured number below the stated range.
By their numbers in this assay, from the lowest: compound 3; then compounds 2 and 1 (each within the scatter of the next).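

Placing pyridin-4-yl in place of phenyl on the saturated chain carbon bound to an aromatic nitrogen gives a 5.3-fold lower number from compound 1 to compound 3 (0.72 log units; beyond the scatter) in this assay, so this part of the molecule can change the read-out by more than the usual scatter. The earlier step, a 1.3-fold lower number from compound 1 to compound 2 (0.11 log units; within the scatter), added a trifluoromethoxy group to the ring and stayed within the scatter, whereas this change keeps the same number of heavy atoms and replaces a ring carbon with a ring nitrogen, showing that the make-up of the ring can matter more here than that added group did. No measurement presented here explains why the number falls with this swap.

Going by these compounds alone, with only one nitrogen-containing ring, it remains open whether the lower number is specific to pyridin-4-yl or would also appear with another ring in the same place, such as a pyrimidine or a thiophene. As far as these compounds go, it is also open whether a substituent such as an amine or a trifluoromethoxy group on the pyridin-4-yl ring would keep the number low.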